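This account rests on a few compounds, and the source may have more. Where it says the series, first, only, none or still open, it means among the compounds named here.

Measured so far:
Compound 1 `COC(=O)c1cc(=O)c2c(OC)cc(OC)cc2n1C` in a functional assay on HepG2 cells (Homo sapiens) for antiproliferative activity, with a stated time of 72 h (a higher number here means that more compound is needed for the effect, a lower number that less compound is needed), gives > 19000 nM, which is a limit of the assay and not a number.
Compound 2 `COC(=O)c1cc(=O)c2c(OC)cc(OC)cc2n1S(=O)(=O)c1ccc(C)cc1` in this assay gives > 20000 nM, likewise a limit.
Compound 3 `COc1ccc(-c2cc(=O)c3c(OC)cc(OC)cc3n2S(=O)(=O)c2ccc(C=O)cc2)cc1` in this assay gives > 34400 nM, again a limit.

Compound 3 therefore has no numeric value in this assay; it sits at a limit, and the two other compounds shown sit at limits as well. The three limits fall at different points where the assay stopped: the limit of > 19000 nM in this assay, at which 1 of the 3 values shown sits, (the limit of > 20000 nM in this assay, at which 1 of the 3 values shown sits), (the limit of > 34400 nM in this assay, at which 1 of the 3 values shown sits). Within the data shown here, nothing in these values orders the compounds relative to one another, and no measured step between any two of them exists.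

Compound 4 `COc1ccc(-c2cc(=O)c3c(OC)cc(OC)cc3n2S(=O)(=O)c2ccc(Cl)cc2)cc1` differs from compound 3 by chloro in place of formyl on an aromatic carbon of a six-membered aromatic ring of carbon only, para to a large group. Among the measured compounds shown here, no measured step of this kind is available to anchor a size or a direction. The expected step in this assay is an at least 1.0-fold lower number from compound 3 to compound 4 (0.00 log units; that floor lies within the scatter), that is, none beyond the scatter, with the assay most likely reporting only a limit once more. Compound 4 is estimated at 34000 nM in this assay, with a range from 10000 nM to 120000 nM.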

Compound 4, half-maximal effective concentration: > 34400 nM
Compound 4: a limit, no number; the forecaster's own chance of this, stated with the estimate: 75%; at least 1.0-fold (0.00 log units) between middle value and limit.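

Compound 3 and compound 4 both give limits, not numbers, in this assay, so no step can be read for chloro in place of formyl: the limit of > 34400 nM in this assay, at which 2 of the 4 values shown sit. The compounds shown leave open whether any member of this series gives a numeric value in this assay, and how changes on the shared core would rank.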